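Tetrabromo core: bromophenyl in place of chlorophenyl

This account rests on a few compounds, and the source may have more. Where it says the series, first, only, none or still open, it means among the compounds named here.

Compound 1 `OC(CCn1nc2c(Br)c(Br)c(Br)c(Br)c2n1)c1ccc(F)cc1`: 46%
Compound 2 `OC(CCn1nc2c(Br)c(Br)c(Br)c(Br)c2n1)c1cccc(Cl)c1`: 71%
Compound 3 `C[C@H](O)CCn1nc2c(Br)c(Br)c(Br)c(Br)c2n1`: 86%

In a functional assay on CCRF-CEM cells (Homo sapiens) for antiproliferative activity, read by MTT assay, with a stated time of 24 h, tested at 50 uM (a lower number here means a stronger effect, a higher number a weaker effect of the compound at the concentration tested), compound 2 gives 71% and stands second highest of the three numbers; compound 3 lies above it, beyond the scatter, and compound 1 below it, also beyond the scatter. Compound 4 `OC(CCn1nc2c(Br)c(Br)c(Br)c(Br)c2n1)c1ccc(Br)cc1` has not been measured. It differs from compound 2 by 4-bromophenyl in place of 3-chlorophenyl on a saturated chain carbon bound to an oxygen on a saturated carbon and a saturated chain carbon. Within the data shown here, the only measured step that exchanges one halophenyl group for another is a number 25 percentage points higher from compound 1 to compound 2 (beyond the scatter), which shows that such an exchange on this core can shift the read-out by a modest amount beyond the scatter. Among the measured compounds shown here, no step exchanges 3-chlorophenyl for 4-bromophenyl directly, so the direction is uncertain; a 4-bromophenyl compound is expected to land between the numbers of compound 1 and compound 2, with a step of a number 15 percentage points lower from compound 2 to compound 4 (beyond the scatter). Compound 4 is therefore estimated at 56%, with a range from 36% to 78%.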

Compound 4, a percentage reported as activity, at one concentration (the size of the read-out at that concentration, not a potency): 58%
Estimate against measurement, compound 4: 2 percentage points below; the measured number falls inside the stated range.
By their numbers in this assay, from the lowest: compound 1; then compound 4; then compound 2; then compound 3.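

In this assay, the step of a number 12 percentage points higher from compound 1 to compound 4 (beyond the scatter) comes from bromo in place of fluoro on an aromatic carbon, and this shows that the identity of the halogen alone shifts the read-out on the shared core, which the earlier step, changing both halogen and ring placement, could not show. The step of a number 13 percentage points lower from compound 2 to compound 4 (beyond the scatter) adds a second exchange at the same saturated chain carbon, and both steps lie beyond the scatter. No evidence is available to explain either shift.

A 4-chlorophenyl group would separate the effect of the halogen from that of its placement, which 3-chlorophenyl and 4-bromophenyl leave entangled. On these data alone, whether an unsubstituted phenyl, or a phenyl carrying an amine or a carboxylic acid, would fall in the same range stays open.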